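Moving a methyl group on the oxadiazole-linked phenyl ring

This account rests on a few compounds, and the source may have more. Where it says the series, first, only, none or still open, it means among the compounds named here.

Measured compounds:
compound 1 `N#Cc1ccc(-c2cnc3[nH]cc(-c4nnc(-c5ccc(Cl)cc5)o4)c(=O)c3c2)cc1` 12.7%
compound 2 `Cc1ccc(-c2nnc(-c3c[nH]c4ncc(-c5ccc(S(C)(=O)=O)cc5)cc4c3=O)o2)cc1` 8.94%
compound 3 `O=c1c(-c2nnc(-c3ccc(Cl)cc3)o2)c[nH]c2ncc(-c3ccccc3)cc12` 14.9%

In a functional assay on HepG2 cells (Homo sapiens) for inhibition, read by MTT assay, with a stated time of 24 h, tested at 10 uM (on this read-out lower numbers stand for less inhibition of growth and higher numbers for more inhibition of growth at the one concentration tested), compound 2 gives 8.94%, the lowest of the three numbers, though its gaps to compound 1 and compound 3 both lie within the scatter. Compound 4 `Cc1cccc(-c2nnc(-c3c[nH]c4ncc(-c5ccc(S(C)(=O)=O)cc5)cc4c3=O)o2)c1` has not been measured; it differs from compound 2 only in this way: 3-methylphenyl in place of 4-methylphenyl on an aromatic carbon. Among the measured compounds shown here, the single measured step, a number 2.2 percentage points higher from compound 1 to compound 3 (within the scatter), changes a different part of the shared core and lies within the scatter, so it says nothing directly about this change. With all three known numbers close together, no step beyond the scatter is expected in this assay for compound 4, in either direction. Compound 4 is therefore estimated at 11%, with a range from 2% to 21%, a step of a number 2.1 percentage points higher from compound 2 to compound 4 (within the scatter) that is expected to stay within the scatter.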

Compound 4, percent growth inhibition at one concentration: 13.3%
Compound 4: middle estimate off by 2.3 percentage points, on the low side; low and high end bracket the measured number.
By their numbers in this assay, from the lowest: compounds 2, 1, 4 and 3 (each within the scatter of the next).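

In this assay, replacing 4-methylphenyl with 3-methylphenyl on the oxadiazole gives a number 4.4 percentage points higher from compound 2 to compound 4 (within the scatter). Among the compounds shown here, this is the first measured change at this phenyl ring, and it shows that moving the methyl group, with the same atoms joined differently, does not shift the growth inhibition beyond the usual scatter at the one concentration tested. No other measurement bears on this result.

As far as these compounds go, whether an amine or a carboxylic acid in place of the methyl would give a step beyond the scatter remains open. The same applies to a longer chain such as propyl.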